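The source may report more compounds than this note shows. Statements on the series, on what has been measured and on what is new or still open speak of the compounds shown alone.

Compound 1, `CCOC(=O)C1=C(Nc2ccccc2)S/C(=C\c2cc(OC)ccc2OC)C1=O`: in a functional assay on MCF7 cells (Homo sapiens) for inhibition, read by MTT assay, with a stated time of 72 h, tested at 10 uM (on this read-out lower numbers stand for less inhibition and higher numbers for more inhibition at the one concentration tested (going by the name of the read-out)), compound 1 reports only a limit, < 10%.
Compound 2, `CCOC(=O)C1=C(Nc2ccccc2)S/C(=C\c2ccc[nH]2)C1=O`: in this assay compound 2 gives 18.3%.
Compound 3, `CCOC(=O)C1=C(Nc2ccc(Br)cc2)S/C(=C\c2ccc[nH]2)C1=O`: in this assay compound 3 reports only a limit, < 10%.

Compound 3 thus stands at the limit of < 10% in this assay, at which 2 of the 3 values shown sit, with no number of its own. Among the measured compounds shown here, the only measured step reaching it, a number at least 8.3 percentage points lower from compound 2 to compound 3 (that floor lies within the scatter), is bromo in place of hydrogen on an aromatic carbon and does not exceed the scatter. Compound 4, `CCOC(=O)C1=C(Nc2ccc(F)cc2)S/C(=C\c2ccc[nH]2)C1=O`, differs from compound 3 by fluoro in place of bromo on an aromatic carbon. For the measured compounds named here, no measured step compares fluoro with bromo; the sole guide is that a halogen at this place left compound 2 and compound 3 within scatter of each other. The step of a number no lower from compound 3 to compound 4 (the limit leaves the size open) is therefore expected to be small, not beyond the scatter. Compound 4 is estimated at 10% (3% to 20%), with a fair chance that only the limit is reported.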

Compound 4, a percentage reported as inhibition, at one concentration (the size of the read-out at that concentration, not a potency): < 10%
Compound 4 ended at the assay's limit; the forecaster's own chance of this, stated with the estimate: 50%; the middle value lies on the limit itself.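

Fluoro in place of hydrogen, para to a large group, gives a number at least 8.3 percentage points lower from compound 2 to compound 4 (that floor lies within the scatter), so compound 4 joins compound 3 and bromo is no longer the only halogen tested at this place. The step between these two halogens cannot be read, as both compounds report only limits. The series now gathers at the floor of this assay: the limit of < 10% in this assay, at which 3 of the 4 values shown sit.

On these data alone, whether fluoro and bromo differ at all stays open. Also open, as far as these compounds go, is what an amine or a carboxylic acid at this place would give, and whether any replacement of hydrogen here moves the number beyond the scatter.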